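The compounds below may be only part of what the source reports. "The series", "measured", "known", "first", "only" and "open" are said of these compounds alone.

Compound 1 `Oc1ccc(CNc2cc(C(F)(F)F)cc3[nH]ncc23)cc1` is tested in an assay for inhibition of Tryptophan 2,3-dioxygenase (Homo sapiens), with stated times of 10 min and 60 min, tested at 100 uM (a higher number here means a stronger effect of the compound at the concentration tested, a lower number a weaker effect), where compound 1 gives 91%. Going by the values given here, its only measured companion, compound 2 `Oc1ccc(CNc2cc(C(F)(F)F)cc3[nH]ncc23)c(Cl)c1`, gives 97% in this assay; the single step known, a number 6 percentage points higher from compound 1 to compound 2 (within the scatter), is within the scatter, so compound 1 stands lowest of the two numbers only in name and cannot be called less active than compound 2.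

Compound 3 `Nc1cccc(CNc2cc(C(F)(F)F)cc3[nH]ncc23)c1` is not yet measured. It differs from compound 1 by 3-aminophenyl in place of 4-hydroxyphenyl on a saturated chain carbon bound to a nitrogen on an aromatic ring. Among the compounds with values here, the one measured step, chloro in place of hydrogen on an aromatic carbon, touches a different part of the molecule and was within the scatter, so no measured step bears directly on this exchange of the whole ring. With both measured compounds near the top of the scale, the expected step of a number 19 percentage points lower from compound 1 to compound 3 (beyond the scatter) in this assay is uncertain but more likely downward than upward. For compound 3 the estimated inhibition is 72%, within a range from 35% to 97%.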

Compound 3, a percentage reported as inhibition, at one concentration (the size of the read-out at that concentration, not a potency): 89%
Beside the measured number, compound 3's estimate is 17 percentage points below it; measured number inside the range.
By their numbers in this assay, from the lowest: compounds 3, 1 and 2 (each within the scatter of the next).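

In this assay, the exchange of the whole ring on the saturated chain carbon gives a number 2 percentage points lower from compound 1 to compound 3 (within the scatter), so 3-aminophenyl stands in for 4-hydroxyphenyl with no readable change. The earlier step showed only that a chloro could be added to the ring that carries the hydroxyl; this one shows that compound 3, which has no hydroxyl and carries an amino group instead, still gives 89%. Nothing at hand explains why the number holds across this exchange.

All three compounds lie near the top of the scale at a single concentration, so any difference in potency among them remains hidden. As far as these compounds go, whether an unsubstituted phenyl, a carboxylic acid on the ring or a longer chain at this place would keep the number stays open.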